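The compounds below may be only part of what the source reports. "The series", "measured", "known", "first", "only" and "open" are said of these compounds alone.

Measured compounds:
- Compound 1 `NCCCOc1ccc(CN(C(=O)c2ccccc2OCCCN)c2nc3ccc(Oc4ccc(O)cc4)cc3s2)cc1`: 3180 nM
- Compound 2 `NCCCOc1ccccc1C(=O)N(Cc1ccc(OCCCN=C(N)N)cc1)c1nc2ccc(Oc3ccccc3)cc2s1`: 3080 nM

In an assay on isolated protein for inhibition of Voltage-dependent N-type calcium channel subunit alpha-1B (Rattus norvegicus) (on this read-out higher numbers stand for an effect only at larger amounts of compound and lower numbers for an effect already at smaller amounts), compound 1 gives 3180 nM and compound 2 gives 3080 nM; the two numbers sit within the scatter of each other, so neither is separated from the other. Compound 3 `NCCCOc1ccccc1C(=O)N(Cc1ccc(OCCCN=C(N)N)cc1)c1nc2ccc(Oc3ccc(O)cc3)cc2s1` differs from compound 2 by hydroxy in place of hydrogen on an aromatic carbon. Going by the values given here, no measured pair isolates this change. Compound 1 carries the same hydroxy group on its phenoxy ring and lands close to compound 2, so compound 3 is expected to show no shift beyond the scatter in this assay, a step of a 1.0-fold lower number from compound 2 to compound 3 (0.01 log units; within the scatter). Compound 3 is estimated at 3000 nM, between 1500 nM and 6000 nM.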

Compound 3, half-maximal effective concentration: 1780 nM
Estimate against measurement, compound 3: 1.7-fold (0.23 log units) above; measured number inside the range.
By their numbers in this assay, from the lowest: compounds 3, 2 and 1 (each within the scatter of the next).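

In this assay, the 4-hydroxyphenoxy group can now be read directly against phenoxy: hydroxy in place of hydrogen gives a 1.7-fold lower number from compound 2 to compound 3 (0.24 log units; within the scatter) and so does not separate the two compounds at this position. With that hydroxy group held constant, the guanidino chain end in place of the amine gives a 1.8-fold lower number from compound 1 to compound 3 (0.25 log units; within the scatter) and is likewise not separated. Neither change therefore moves the number beyond the scatter in this pair of comparisons. From the compounds shown here alone, whether a methoxy group or a fluorine at the same ring position would behave alike remains open. No measurement shown gives a reason for either step.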